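From hydroxycarbamoyl to a longer methylcarbamoyl chain

A few compounds are considered here, and "the series" means these few. Any claim that something is new, unique, unknown or untested is made for them only; others in the source may bear on it.

In a functional assay on MCF7 cells (Homo sapiens) for inhibition, read by MTT assay, with a stated time of 72 h (on this read-out higher numbers stand for weaker inhibition and lower numbers for stronger inhibition), compound 2 (`Nc1nc2cc(-c3nn(CCC(=O)NO)c4ncnc(N)c34)ccc2o1`) gives > 100000 nM as a limit, not a number. Compound 1 (`Nc1ncnc2c1c(-c1cnc3[nH]ccc3c1)nn2CC(=O)NO`) gives > 150000 nM as a limit too. Compound 3 (`Nc1ncnc2c1c(-c1cnc3[nH]ccc3c1)nn2CCCC(=O)NO`) likewise gives > 150000 nM as a limit. Compound 4 (`CNC(=O)CCCCCCCn1nc(-c2ccc3oc(N)nc3c2)c2c(N)ncnc21`) carries 5-(methylcarbamoyl)pentyl in place of hydroxycarbamoyl on a saturated chain carbon, two bonds along the chain from an aromatic nitrogen, and 5-(methylcarbamoyl)pentyl in place of hydroxycarbamoyl on a saturated chain carbon, two bonds along the chain from an aromatic nitrogen is the whole change. Among the compounds with values here, the one measured step that bears on this, a step that the two limits leave unreadable from compound 1 to compound 3, also alters the chain, but it offers no size to carry over. In this assay only a small step toward stronger inhibition is therefore expected, and it is loosely estimated as an at least 1.6-fold lower number from compound 2 to compound 4 (0.22 log units; that floor lies within the scatter) here. For compound 4 the estimate is 60000 nM, within an expected range of 5000 nM to 150000 nM overall.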

Compound 4, half-maximal inhibitory concentration: 7220 nM
Estimate against measurement, compound 4: 8.3-fold (0.92 log units) above; the measured number falls inside the stated range.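

Within the data shown here, putting 5-(methylcarbamoyl)pentyl in place of hydroxycarbamoyl at this position gives an at least 13-fold lower number from compound 2 to compound 4 (1.14 log units; beyond the scatter) in this assay, the first readable step. The value of compound 2 is a limit, not a number: the limit of > 100000 nM in this assay, at which 1 of the 4 values shown sits. The earlier step from compound 1 to compound 3 cannot be read.

This change alters the end group and the chain length together, and the compounds shown do not separate the two. Going by these compounds, how a carboxylic acid at the end of the longer chain would read also remains open.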